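Swapping Thiophene for Phenyl: Expected Growth Inhibition

The compounds below may be only part of what the source reports. "The series", "measured", "known", "first", "only" and "open" are said of these compounds alone.

Three compounds have been measured in a functional assay on HCT-116 cells (Homo sapiens) for inhibition, read by sulforhodamine B assay, with a stated time of 48 h; a lower number here means a stronger inhibitor of growth, a higher number a weaker inhibitor of growth:

compound 1, `CC1CCCc2c1nc(N)c(C#N)c2-c1cccn1C` — > 100000 nM, a limit rather than a number
compound 2, `Cn1cccc1-c1cc(-c2cccs2)nc(N)c1C#N` — > 100000 nM, a limit rather than a number
compound 3, `Cn1cccc1-c1cc(-c2cccs2)[nH]c(=O)c1C#N` — > 100000 nM, a limit rather than a number

Compound 2 therefore has no measured number in this assay, only a limit, and the two other compounds stand at the same limit. This is summed up by the limit of > 100000 nM in this assay, at which 3 of the 3 values shown sit. Among the compounds with values here, with all three values at the limit, no step between measured compounds can be worked out, so there is no measured trend to lean on.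

Compound 4, `Cn1cccc1-c1cc(-c2ccccc2)nc(N)c1C#N`, is not yet measured. It differs from compound 2 in one place: phenyl in place of thiophen-2-yl on an aromatic carbon. In words, phenyl in place of thiophen-2-yl on an aromatic carbon.

Since compound 2 sits at the limit, the expected step from compound 2 to compound 4 cannot be taken from a measured pair; the expectation is that the change leaves compound 4 at or near the limit, so a step that the limit leaves unreadable from compound 2 to compound 4 is estimated as no step beyond the scatter. Compound 4 is therefore expected to give 150000 nM in this assay, with a range from 30000 nM to 600000 nM, most likely reported again only as a limit.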

Compound 4, concentration for 50% growth inhibition: > 100000 nM
Compound 4 gave a limit, no number; the forecaster's own chance of this, stated with the estimate: 85%; the middle value lies beyond the limit too.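

Compound 2 and compound 4 are both known only as limits, not numbers, so no step can be read for phenyl in place of thiophen-2-yl. The whole set looks the same: the limit of > 100000 nM in this assay, at which 4 of the 4 values shown sit.

The compounds shown leave open whether any of them would give an actual number in this assay, and so whether phenyl or thiophen-2-yl makes any difference there.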